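The compounds below may be only part of what the source reports. "The series", "measured", "known", "first", "only" and "open" are said of these compounds alone.

Measured so far:
- compound 1, `NC(=O)Cc1cc(=O)oc2cc(OCc3ccccc3)ccc12`: in an assay (strain Wistar) for inhibition of Amine oxidase [flavin-containing] A (Rattus norvegicus) (on this read-out higher numbers stand for weaker inhibition and lower numbers for stronger inhibition), compound 1 gives 8000 nM
- compound 2, `CN(C)C(=O)Cc1cc(=O)oc2cc(OCc3ccccc3)ccc12`: in this assay compound 2 gives 23100 nM

Compound 2 stands with the highest number of the two; a 2.9-fold higher number from compound 1 to compound 2 (0.46 log units; beyond the scatter) separates it from compound 1. Compound 3, `NCc1cc(=O)oc2cc(OCc3ccccc3)ccc12`, differs from compound 2 in that (amino in place of dimethylcarbamoyl on a saturated chain carbon bound to an aromatic carbon). Within the data shown here, only the step from compound 1 to compound 2 bears on this change, and only loosely, since that step touched the amide rather than removing it. The amino group enters with one hydrogen-bond donor, as in compound 1, so compound 3 is estimated to return toward the number of compound 1, a step of a 2.3-fold lower number from compound 2 to compound 3 (0.36 log units; beyond the scatter), giving 10000 nM (range 2000 nM to 50000 nM).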

Compound 3, half-maximal inhibitory concentration: 4400 nM
For compound 3 the middle estimate is 2.3-fold (0.36 log units) above the measured one; the range from low to high includes it.
By their numbers in this assay, from the lowest: compounds 3 and 1 (each within the scatter of the next); then compound 2.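

In this assay, the short amino group can take the place of the larger dimethylcarbamoyl group on this saturated chain carbon, with a 5.3-fold lower number from compound 2 to compound 3 (0.72 log units; beyond the scatter). Exchanging carbamoyl for amino at the same place gives a 1.8-fold lower number from compound 1 to compound 3 (0.26 log units; within the scatter), so compound 1 and compound 3 cannot be told apart, and an amide is not required here to reach this level of inhibition. Nothing available explains either result.

Still open, going by these compounds, is how a carboxylic acid or a longer chain ending in an amine would fare at this place.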